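Diethoxymethyl for Carboxyethyl on Two Related Cores

A few compounds are considered here, and "the series" means these few. Any claim that something is new, unique, unknown or untested is made for them only; others in the source may bear on it.

Measured compounds:
compound 1, `CC(C)=CCC[C@H](C)c1ccc(C)c2c1OCN(CCCCC(=O)O)C2`, 29900 nM
compound 2, `CC(C)=CCC[C@H](C)c1ccc(C)c(CNCCCCC(=O)O)c1O`, > 20000 nM
compound 3, `CCOC(CCN1COc2c([C@@H](C)CCC=C(C)C)ccc(C)c2C1)OCC`, 3100 nM

Of the compounds shown here, three have been measured in a functional assay on MDA-MB-231 cells (Homo sapiens), read by wound healing assay, with a stated time of 24 h; on this read-out higher numbers stand for weaker inhibition and lower numbers for stronger inhibition. Compound 1 `CC(C)=CCC[C@H](C)c1ccc(C)c2c1OCN(CCCCC(=O)O)C2` gives 29900 nM in this assay. Compound 3 `CCOC(CCN1COc2c([C@@H](C)CCC=C(C)C)ccc(C)c2C1)OCC` gives 3100 nM. The change between them is diethoxymethyl in place of 2-carboxyethyl on a saturated chain carbon, two bonds along the chain from an amine nitrogen in a ring, and it made a step of a 9.6-fold lower number from compound 1 to compound 3 (0.98 log units; beyond the scatter). Compound 2 `CC(C)=CCC[C@H](C)c1ccc(C)c(CNCCCCC(=O)O)c1O` returns only a limit in this assay, > 20000 nM, which is the limit of > 20000 nM in this assay, at which 1 of the 3 values shown sits. The difference between the core of compound 1 and the core of compound 2 is not broken down here.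

Compound 4 `CCOC(CCNCc1c(C)ccc([C@@H](C)CCC=C(C)C)c1O)OCC` has not yet been measured. It differs from compound 2 by diethoxymethyl in place of 2-carboxyethyl on a saturated chain carbon, two bonds along the chain from an amine nitrogen. This is the same kind of change as from compound 1 to compound 3, with the difference that there the amine nitrogen is in a ring and here it is not. The step expected in this assay is an at least 3.3-fold lower number from compound 2 to compound 4 (0.52 log units; beyond the scatter), which rests on the earlier step of a 9.6-fold lower number from compound 1 to compound 3 (0.98 log units; beyond the scatter) and on the fact that compound 2 gives only a limit. Compound 4 is thus estimated at 6000 nM, with a range from 2000 nM to 30000 nM.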

Compound 4, half-maximal inhibitory concentration: > 20000 nM
Compound 4 gave a limit, no number; the forecaster's own chance of this, stated with the estimate: 25%; middle value at least 3.3-fold (0.52 log units) from the limit.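

Compound 4 returned only a limit in this assay and compound 2 did the same, so the step between the two cannot be read: the limit of > 20000 nM in this assay, at which 2 of the 4 values shown sit. The compounds shown leave open whether diethoxymethyl in place of 2-carboxyethyl lowers the number on the core of compound 2, as it does on the core of compound 1.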